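Swapping the sulfonyl aryl group on a quinazoline core

The compounds below may be only part of what the source reports. "The series", "measured", "known", "first", "only" and "open" are said of these compounds alone.

Measured compounds:
- compound 1, `COc1cc2nc(N3CCN(S(=O)(=O)c4ccccc4[N+](=O)[O-])CC3)nc(N)c2cc1OC`: 35000 nM
- compound 2, `COc1cc2nc(N3CCN(S(=O)(=O)c4ccc(N)cc4N)CC3)nc(N)c2cc1OC`: 67000 nM

Compound 1 and compound 2 share a core and differ only in the aryl group on the sulfonyl sulfur. In a functional assay on PC-3 cells (Homo sapiens) for inhibition (on this read-out higher numbers stand for weaker inhibition and lower numbers for stronger inhibition), compound 2 gives 67000 nM, the higher of the two numbers, yet the step of a 1.9-fold higher number from compound 1 to compound 2 (0.28 log units; within the scatter) stays within the scatter. Compound 3, `COc1cc2nc(N3CCN(S(=O)(=O)c4cc(F)c(Cl)c(C(=O)O)c4)CC3)nc(N)c2cc1OC`, carries the change (3-carboxy-4-chloro-5-fluorophenyl in place of 2,4-diaminophenyl on a sulfonyl sulfur). Among the measured compounds shown here, no measured step covers this exact exchange; the only step recorded, swapping one aryl group for another, moved the number little. A similar outcome is therefore expected, with the estimated step of a 1.3-fold lower number from compound 2 to compound 3 (0.13 log units; within the scatter) not clearly beyond the scatter. Compound 3 is expected to give 50000 nM, within 15000 nM to 150000 nM.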

Compound 3, half-maximal inhibitory concentration: 56000 nM
Beside the measured number, compound 3's estimate is 1.1-fold (0.05 log units) below it, and the stated range covers the measured number.
By their numbers in this assay, from the lowest: compounds 1, 3 and 2 (each within the scatter of the next).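

In this assay, a third aryl group on the sulfonyl sulfur stays within the scatter of both earlier ones, with a 1.2-fold lower number from compound 2 to compound 3 (0.08 log units; within the scatter) and a 1.6-fold higher number from compound 1 to compound 3 (0.20 log units; within the scatter). Even 3-carboxy-4-chloro-5-fluorophenyl, which brings a carboxylic acid and two halogens, cannot be told apart from 2,4-diaminophenyl or 2-nitrophenyl at this position. No supporting data offer an explanation for this flat result.

Going by these compounds, all three groups place a six-membered aromatic ring on the sulfur, so the effect of a cyclohexyl ring or a short alkyl chain there remains open. Also open, on these data alone, is whether any group at this position can move the number beyond the scatter.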